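Working notes: compound 4 against compounds 1 to 3

The source may report more compounds than this note shows. Statements on the series, on what has been measured and on what is new or still open speak of the compounds shown alone.

Measured so far in an assay on SH-SY5Y cells for inhibition of Voltage-dependent N-type calcium channel subunit alpha-1B (Homo sapiens), read by FLIPR and calcium flux, with stated times of 600 s and 300 s, in the presence of a further agent that is not named here; on this read-out lower numbers stand for stronger inhibition and higher numbers for weaker inhibition:
compound 1, `CN(Cc1ccc(OCCCN)cc1)c1nc2ccc(Oc3ccc(C#N)cc3)cc2s1`, 65000 nM
compound 2, `CN(Cc1ccc(OCCCN)cc1)c1nc2ccc(Oc3ccc(C(F)(F)F)cc3)cc2s1`, 283000 nM
compound 3, `CN(Cc1ccc(OCCCNC(=N)N)cc1)c1nc2ccc(Oc3ccc(F)cc3)cc2s1`, 100000 nM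

Compound 3 holds the second highest of the three numbers in this assay. Its nearest neighbour is compound 1, whose value lies within the scatter of that of compound 3, so no order between these two can be stated. Its furthest neighbour is compound 2, whose value stands beyond the scatter above that of compound 3.

Compound 4, `CN(Cc1ccc(OCCCN)cc1)c1nc2ccc(Oc3ccc(F)cc3)cc2s1`, differs from compound 3 in one place: a hydrogen atom in place of a group of 3 heavy atoms (1 carbon, 2 nitrogen; no ring), on an amine nitrogen. Within the data shown here, the only measured step, a 4.4-fold higher number from compound 1 to compound 2 (0.64 log units; beyond the scatter), concerns an exchange on the aromatic ring and does not touch the amine end of the chain, so it does not bear on this change. A measured amine-bearing compound, compound 1, and the guanidine-bearing compound 3 sit within the scatter of each other, though they also differ on the ring. In this assay compound 4 is therefore expected to show no step beyond the scatter, no change at the digits printed from compound 3 to compound 4 (within the scatter). The estimate for compound 4 in this assay is 100000 nM, with a range from 35000 nM to 300000 nM.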

Compound 4, half-maximal inhibitory concentration: 98000 nM
Beside the measured number, compound 4's estimate is 1.0-fold (0.01 log units) above it; the measured number falls inside the stated range.
By their numbers in this assay, from the lowest: compounds 1, 4 and 3 (each within the scatter of the next); then compound 2.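

In this assay, among these compounds, hydrogen in place of the group of 3 heavy atoms (1 carbon, 2 nitrogen; no ring) on the amine nitrogen gives a 1.0-fold lower number from compound 3 to compound 4 (0.01 log units; within the scatter), the first direct reading at this position, and it does not separate the two chain ends. With the amine end held fixed, the aromatic substituent can now be read against fluoro: fluoro in place of trifluoromethyl gives a 2.9-fold lower number from compound 2 to compound 4 (0.46 log units; beyond the scatter), while fluoro in place of cyano gives a 1.5-fold higher number from compound 1 to compound 4 (0.18 log units; within the scatter), so among these three compounds only trifluoromethyl stands apart. No measurement shown accounts for either result.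

The compounds shown leave open whether the chain-end exchange reads the same with cyano or trifluoromethyl on the ring, since it is seen only with fluoro. They also leave open what an acetamide, a carboxylic acid or a longer chain at this end would give.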